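Methyl on the Pyrrole Nitrogen Across Two Different Cores

The compounds below may be only part of what the source reports. "The series", "measured", "known", "first", "only" and "open" are said of these compounds alone.

Of the compounds shown here, three have so far been measured in a functional assay on the whole organism (strain Wistar Albino) for inhibition, with Rattus norvegicus as the target, read by paw edema, with a stated time of 1 h, at a dose of 20 mg/kg; on this read-out higher numbers stand for more inhibition at the one dose given (going by the name of the read-out) and lower numbers for less inhibition. Compound 1 `COc1ccc(Cl)c(-c2nnc3n2NC(c2ccc[nH]2)S3)c1` carries an unsubstituted pyrrole, and in this assay compound 1 gives 12.8%. Compound 3 `COc1ccc(Cl)c(-c2nnc3n2NC(c2cccn2C)S3)c1` differs from compound 1 only by methyl in place of hydrogen on an aromatic nitrogen. In this assay compound 3 gives 14.1%, so the step is a number 1.3 percentage points higher from compound 1 to compound 3 (within the scatter) and does not rise above the noise of repeated measurement.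

Compound 2 `COc1ccc(Cc2nnc3n2NC(c2ccc[nH]2)S3)cc1OC` rests on a second core; how the two cores differ is not broken down here. In this assay compound 2 gives 13.2%, a number that sits among those of compound 1 and compound 3 without any separation that the scatter would allow one to read as real.

Compound 4 `COc1ccc(Cc2nnc3n2NC(c2cccn2C)S3)cc1OC` has not yet been measured. It stands to compound 2 as compound 3 stands to compound 1, since the difference is methyl in place of hydrogen on an aromatic nitrogen, the same change made on the other core. Going by the values given here, with only one instance of this change measured, its step on the second core is expected to look like the first: an estimated a number 1.3 percentage points higher from compound 2 to compound 4 (within the scatter), resting on the fact that the change from compound 1 to compound 3 gave a number 1.3 percentage points higher from compound 1 to compound 3 (within the scatter). On that basis compound 4 is estimated to give 14.5% in this assay, with an expected range from 8% to 21%.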

Compound 4, a percentage reported as inhibition, in the whole organism at one dose (the size of the read-out at that dose, not a potency): 13.4%
For compound 4 the middle estimate is 1.1 percentage points above the measured one; the measured number falls inside the stated range.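

On the second core, methyl in place of hydrogen on the aromatic nitrogen leaves the result in this assay much as it was, with a number 0.2 percentage points higher from compound 2 to compound 4 (within the scatter). Set beside the step on the core of compound 1, the change reads alike on both cores: the same change on two cores in this assay, a number 1.3 percentage points higher (within the scatter) from compound 1 to compound 3 and a number 0.2 percentage points higher (within the scatter) from compound 2 to compound 4, 1.1 percentage points apart, within the scatter of two such steps This agreement is only between two steps that each stay inside the scatter, so it shows that going from 1H-pyrrol-2-yl to 1-methyl-1H-pyrrol-2-yl has no detectable effect on either core at this one dose and time, but it does not show that the methyl does anything real, nor that a step large enough to stand clear of the scatter would carry from one core to the other in the same way.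

The compounds shown hold only hydrogen or methyl on that nitrogen, and it remains open whether an ethyl group, a longer chain or a chain ending in a carboxylic acid at the same place would move the number clear of the scatter. Also open, from the compounds shown here alone, is whether the two cores would still read alike at another dose or at a later time.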